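Methylaminomethyl Side Chain on the Biphenyl Thiadiazole Core

The source may report more compounds than this note shows. Statements on the series, on what has been measured and on what is new or still open speak of the compounds shown alone.

Three compounds share a five-membered aromatic ring that carries an aminoalkyl group. Compound 1 `CCCCCCOc1ccccc1-c1nnc(CNC)s1` gives, in a functional assay on the whole organism with Mus musculus as the target (on this read-out higher numbers stand for an effect only at larger amounts of compound and lower numbers for an effect already at smaller amounts), 44 mg/kg. Compound 2 `CC(C)NCc1nnc(-c2ccccc2-c2ccccc2)s1` gives 23 mg/kg in this assay, and compound 3 `CC(N)c1nnc(-c2ccccc2-c2ccccc2)s1` gives 21 mg/kg. Compound 3 thus has the lowest of the three numbers, but compound 2 lies within the scatter of it, and only compound 1 stands apart from it beyond the scatter.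

Compound 4 `CNCc1nnc(-c2ccccc2-c2ccccc2)s1` is not yet measured. It differs from compound 3 in one place: (methylamino)methyl in place of 1-aminoethyl on an aromatic carbon.

Within the data shown here, one measured step bears on this change, as it also exchanges the side chain at the same position of the same core: a 1.1-fold lower number from compound 2 to compound 3 (0.04 log units; within the scatter), within the scatter. Compound 1 carries the same (methylamino)methyl group as compound 4, yet on a different core, so its higher number cannot be read as a step. On this basis the exchange of one small aminoalkyl group for another on this core is expected to leave the number essentially unchanged.

Compound 4 is therefore estimated at 22 mg/kg, with a range from 10 mg/kg to 48 mg/kg, which means an expected step of a 1.0-fold higher number from compound 3 to compound 4 (0.02 log units; within the scatter).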

Compound 4, dose for half-maximal effect: 25 mg/kg
The estimate for compound 4 lay 1.1-fold (0.06 log units) below the measured number, and the stated range covers the measured number.
By their numbers in this assay, from the lowest: compounds 3, 2, 4 and 1 (each within the scatter of the next, the first and the last beyond it).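

On the shared core, swapping one small aminoalkyl group for another at this position makes no reading difference in this assay: the exchange of 1-aminoethyl for (methylamino)methyl gives a 1.2-fold higher number from compound 3 to compound 4 (0.08 log units; within the scatter), and methyl in place of isopropyl on the amine nitrogen gives a 1.1-fold higher number from compound 2 to compound 4 (0.04 log units; within the scatter), so all three side chains tried on this core lie within the scatter of one another. Compound 4 also gives the first one-place link to compound 1, which carries the same (methylamino)methyl group, and phenyl in place of hexyloxy gives a 1.8-fold lower number from compound 1 to compound 4 (0.25 log units; within the scatter), so that this exchange on the aromatic carbon also stays within the scatter. The data at hand offer no measured explanation for any of these results.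

From the compounds shown here alone, it remains open whether this position would hold its number with a longer chain on the amine nitrogen, such as hexyl, or with a ring amine such as piperidine. Going by these compounds, it is equally open what a hydroxyl or a carboxylic acid would do in place of the amine.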